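From one aryl group to another on a shared core

The source may report more compounds than this note shows. Statements on the series, on what has been measured and on what is new or still open speak of the compounds shown alone.

In a functional assay on KB cells (Homo sapiens) for antiproliferative activity, read by sulforhodamine B assay, with a stated time of 3 days (on this read-out lower numbers stand for an effect already at smaller amounts and higher numbers for an effect only at larger amounts of compound), compound 1 `CCC1=C(O)c2c(oc(-c3cccc(C)c3)cc2=O)C(CC)(CC)C1=O` gives 49.7 uM and compound 2 `CCC1=C(O)c2c(oc(-c3ccc(OC)c(F)c3)cc2=O)C(CC)(CC)C1=O` gives 26.7 uM. Within the data shown here, these two numbers are all that is known so far, and they lie within the scatter of each other, so compound 2 cannot be separated from its only measured neighbour.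

Compound 3 `CCC1=C(O)c2c(oc(-c3cc(C)ccc3F)cc2=O)C(CC)(CC)C1=O` keeps the shared core and changes only the aryl group: 2-fluoro-5-methylphenyl in place of 3-fluoro-4-methoxyphenyl on an aromatic carbon. The 2-fluoro-5-methylphenyl group stands in place of 3-fluoro-4-methoxyphenyl on the same aromatic carbon, next to the ring oxygen.

Among the measured compounds shown here, only one measured step bears on this change: a 1.9-fold lower number from compound 1 to compound 2 (0.27 log units; within the scatter). The 3-methylphenyl group of compound 1 and the 3-fluoro-4-methoxyphenyl group of compound 2 each share a substituent with the entering group. As that single exchange stayed within the scatter, no clear change is expected here, and no firm direction can be given. The estimated step is a 1.3-fold higher number from compound 2 to compound 3 (0.12 log units; within the scatter), which is expected to remain within the scatter. Compound 3 is expected at about 35 uM, with an estimated range from 15 uM to 80 uM.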

Compound 3, concentration for half-maximal effect: 47.3 uM
The estimate for compound 3 lay 1.4-fold (0.13 log units) below the measured number, within the range that was stated.
By their numbers in this assay, from the lowest: compounds 2, 3 and 1 (each within the scatter of the next).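

In this assay, 2-fluoro-5-methylphenyl in place of 3-fluoro-4-methoxyphenyl on the aromatic carbon next to the ring oxygen gives a 1.8-fold higher number from compound 2 to compound 3 (0.25 log units; within the scatter) and so adds a second exchange of aryl groups at this position that stays within the scatter. Among these compounds, the new compound also gives the first pair that differs by one substituent on the aryl group: fluoro in place of hydrogen on an aromatic carbon gives a 1.1-fold lower number from compound 1 to compound 3 (0.02 log units; within the scatter) and leaves compound 3 inseparable from compound 1. Taken together, the three aryl groups at this position, with or without fluoro and with methyl or methoxy, cannot be told apart on this read-out, so the position has not yet shown any response to a change of aryl group.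

Still open, on these data alone, is whether any group on this aryl ring can move the number beyond the scatter, for instance an amine, a carboxylic acid or a longer chain in place of the methyl. Nothing measured here gives a reason for the numbers of these three compounds, or shows whether the fluoro group has any effect of its own.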